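A few compounds are considered here, and "the series" means these few. Any claim that something is new, unique, unknown or untested is made for them only; others in the source may bear on it.

Among the compounds with values here, in a functional assay on HCC827 cells (Homo sapiens) for antiproliferative activity, read by MTT assay, with a stated time of 72 h (on this read-out lower numbers stand for stronger inhibition and higher numbers for weaker inhibition), compound 1 `CN1CCN(c2ccc(Nc3ncc4nc(Sc5ccccc5)n(C5CCOCC5)c4n3)cc2)CC1` gives 42.6 nM, the lower of the two numbers measured so far. Compound 2 `CN1CCN(c2ccc(Nc3ncc4nc([S+]([O-])Cc5ccccc5)n(C5CCOCC5)c4n3)cc2)CC1` gives 433 nM. Compound 3 `CN1CCN(c2ccc(Nc3ncc4nc(SCc5cccnc5)n(C5CCOCC5)c4n3)cc2)CC1` has yet to be measured. It differs from compound 1 as follows: (pyridin-3-yl)methyl in place of phenyl on a sulfur. In short, (pyridin-3-yl)methyl stands in place of phenyl on a sulfur. Within the data shown here, only one measured step bears on this change: a 10-fold higher number from compound 1 to compound 2 (1.01 log units; beyond the scatter). This step is large and beyond the scatter. It also puts a larger group on the same aromatic carbon, but it is only a partial guide. Its group carries an oxygen on the sulfur, which compound 3 lacks, and its ring is carbon only, whereas compound 3 has a ring with a hetero atom. Among the measured compounds shown here, no measured step changes the ring alone. A rise in this assay is therefore expected, in the same direction as that step but smaller. The expected step is a 3.5-fold higher number from compound 1 to compound 3 (0.55 log units; beyond the scatter). For compound 3 the estimated value is 150 nM, with an expected range from 45 nM to 500 nM.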

Compound 3, half-maximal inhibitory concentration: 500 nM
Compound 3: the middle estimate sits 3.3-fold (0.52 log units) below what was measured; the range from low to high includes it.
By their numbers in this assay, from the lowest: compound 1; then compounds 2 and 3 (each within the scatter of the next).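

In this assay, (pyridin-3-yl)methyl in place of phenyl on a sulfur gives a 12-fold higher number from compound 1 to compound 3 (1.07 log units; beyond the scatter), a large step, so the group with a hetero atom in its ring does not recover what was lost with the earlier larger group on the same aromatic carbon. The two larger groups cannot be told apart in this read-out: a 1.2-fold higher number from compound 2 to compound 3 (0.06 log units; within the scatter) lies within the scatter, although one carries an oxygen on the sulfur and a ring of carbon only, while the other has no such oxygen and a ring with a hetero atom. No measurement is available here that would explain either step.

What the compounds shown leave open is whether the large step follows from the added methyl link or from the ring itself, a question that a benzylsulfanyl group and a pyridin-3-yl group placed directly on the sulfur would separate. From the compounds shown here alone, it also remains open whether a longer chain on the sulfur, or an amine on the phenyl ring of compound 1, would keep the number of compound 1 or move it as these larger groups do.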